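A few compounds are considered here, and "the series" means these few. Any claim that something is new, unique, unknown or untested is made for them only; others in the source may bear on it.

Measured in a physicochemical assay for lipophilicity, read by HPLC, at pH 7.5; on this read-out higher numbers stand for higher lipophilicity and lower numbers for lower lipophilicity:
compound 1 `CC[C@@H](Nc1c(C#N)c(-c2ccc(-c3ccccc3C)cc2)nc2cnccc12)C(N)=O`: 3
compound 2 `CC[C@@H](Nc1c(C#N)c(-c2ccc(-c3ccccc3NC)cc2)nc2cnccc12)C(N)=O`: 2.5

Going by the values given here, compound 2 holds the lower of the two numbers, and the single measured step is a number 0.50 log units lower from compound 1 to compound 2 (beyond the scatter). Next in line is compound 3 `CC[C@@H](Nc1c(C#N)c(-c2ccc(-c3ccccc3CO)cc2)nc2cnccc12)C(N)=O`, with the change hydroxymethyl in place of methylamino on an aromatic carbon, ortho to a large group. The step to compound 2 is the only one that bears on this change, since it involves the departing methylamino group. No measurement in the series contains hydroxymethyl, so its guidance is limited. Judged against the modest size of a number 0.50 log units lower from compound 1 to compound 2 (beyond the scatter), only a small shift is expected in this assay, leaning slightly lower and not clearly beyond the scatter. The expected move is a number 0.20 log units lower from compound 2 to compound 3 (within the scatter). For compound 3 the estimated value is 2.3, with an expected range of 1.9 to 2.7.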

Compound 3, distribution coefficient: 2.1
For compound 3 the middle estimate is 0.20 log units above the measured one; low and high end bracket the measured number.
By their numbers in this assay, from the lowest: compound 3; then compound 2; then compound 1.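

In this assay, hydroxymethyl in place of methylamino on this aromatic carbon, ortho to a large group, gives a number 0.40 log units lower from compound 2 to compound 3 (beyond the scatter). The read-out therefore separates these two groups even though their heavy-atom, hydrogen-bond donor and acceptor counts match. Hydroxy in place of hydrogen on the saturated chain carbon gives a number 0.90 log units lower from compound 1 to compound 3 (beyond the scatter), leaving compound 3 with the lowest number of the three, and nothing at hand accounts for either step.

The compounds shown leave open how a longer chain such as hydroxyethyl, an ether such as methoxymethyl, or a carboxylic acid would read at this place. They also leave open whether the swap from 2-(methylamino)phenyl to 2-(hydroxymethyl)phenyl would give a similar step on a different core.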